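This account rests on a few compounds, and the source may have more. Where it says the series, first, only, none or still open, it means among the compounds named here.

Compound 1 `Cc1cccc(C)c1Oc1cc(Nc2ccc(C#N)cc2)[nH]c(=O)c1Br`: 63000 nM
Compound 2 `Cc1cc(C#N)cc(C)c1Oc1cc(Nc2ccc(C#N)cc2)[nH]c(=O)c1Cl`: > 319000 nM (a limit of the assay)

For the measured compounds named here, in an ADME assay on MT4 cells (Homo sapiens) for cytotoxicity, read by MTT assay, with a stated time of 5 days (on this read-out higher numbers stand for lower toxicity in this test and lower numbers for higher toxicity in this test), compound 1 gives 63000 nM, the only actual number available. For compound 2, the entry of > 319000 nM is a limit. Compound 3 `Cc1cccc(C)c1Oc1cc(Nc2ccc(C#N)cc2)[nH]c(=O)c1I` departs from compound 1 at a single place, with iodo in place of bromo on an aromatic carbon. Going by the values given here, no measured pair of compounds isolates this exchange, so no change beyond the usual scatter is expected in this assay. The expected 1.3-fold lower number from compound 1 to compound 3 (0.10 log units; within the scatter) is small and slightly downward. For compound 3, the estimated value is 50000 nM, with an expected range from 20000 nM to 125000 nM.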

Compound 3, half-maximal cytotoxic concentration: 28000 nM
Compound 3: the middle estimate sits 1.8-fold (0.25 log units) above what was measured; the range from low to high includes it.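

In this assay, the halogen on this aromatic carbon turns out to matter: exchanging bromo for iodo gives a 2.3-fold lower number from compound 1 to compound 3 (0.35 log units; beyond the scatter), a modest shift toward higher toxicity in this test. A single heavy atom is exchanged here, with no change in ring, hydrogen-bond donors, hydrogen-bond acceptors or net charge. Nothing in the data shown accounts for this step. From the compounds shown here alone, it remains open whether a fluoro, a methyl or an amine on the same carbon would move the read-out in the same direction.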